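This account rests on a few compounds, and the source may have more. Where it says the series, first, only, none or still open, it means among the compounds named here.

The series shares one core, and the change of interest is at the group on the ring nitrogen. Compound 1 `CC(C)CCn1nc(-c2ccn(C)c2)c(O)c(C2=NS(=O)(=O)c3cc(NS(C)(=O)=O)ccc3N2)c1=O` and compound 2 `CC(C)CCn1nc(C2CCC2)c(O)c(C2=NS(=O)(=O)c3cc(NS(C)(=O)=O)ccc3N2)c1=O` differ only at an aromatic carbon on the side ring. In an in vitro ADME assay on microsomes from liver (Homo sapiens) for metabolic stability, tested at 5 uM (a lower number here means that the compound disappears faster, a higher number that the compound lasts longer), compound 1 gives 0.633 h, and in this assay compound 2 gives 0.317 h. That step, a 2.0-fold lower number from compound 1 to compound 2 (0.30 log units; within the scatter), concerns a position far from the change considered here, and it stays within the scatter.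

Compound 3 `CS(=O)(=O)Nc1ccc2c(c1)S(=O)(=O)N=C(c1c(O)c(-c3cccs3)nn(CCC3CC3)c1=O)N2` carries a thiophene on the side ring and a cyclopropylmethyl on the ring nitrogen. In this assay compound 3 is reported only as a limit, > 1 h, and not as a number; this is the limit of > 1 h in this assay, at which 1 of the 3 values shown sits.

Compound 4 `CS(=O)(=O)Nc1ccc2c(c1)S(=O)(=O)N=C(c1c(O)c(-c3cccs3)nn(Cc3ccccc3)c1=O)N2` is the analogue with phenyl in place of cyclopropylmethyl on a saturated chain carbon bound to an aromatic nitrogen. No measured step touches this chain position, so the one step shown, which is within the scatter, gives no direction for it. With compound 3 already sitting at the limit of this assay, the expectation for compound 4 is that it stays near that limit, with a step that the limit leaves unreadable from compound 3 to compound 4, which means no change beyond the scatter. Compound 4 is therefore estimated at 1.2 h, within a range from 0.5 h to 3 h, with a fair chance that this assay again reports only a limit.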

Compound 4, half-life: > 1 h
Compound 4 gave a limit, no number (the forecaster's own chance of this, stated with the estimate: 55%); the middle value lies beyond the limit too.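

In this assay, compound 3 and compound 4 are both reported only as limits and not as numbers, so no step can be read from compound 3 to compound 4: the limit of > 1 h in this assay, at which 2 of the 4 values shown sit.

The compounds shown leave open whether phenyl in place of cyclopropylmethyl on a saturated chain carbon bound to an aromatic nitrogen changes the half-life at all, and in which direction.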